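The source may hold more compounds than are shown below. What is called first, only, known or untested is meant among the compounds shown, and "the series" means these compounds.

Measured compounds:
- compound 1, `O=c1c(C2=CS(=O)(=O)c3cc(O)ccc3N2)c(O)c2cc(F)ccc2n1Cc1ccc(F)cc1`; in an ADME assay on 2209-23 cells (Homo sapiens) for cytotoxicity, read by WST assay (a lower number here means that less compound is tolerated, a higher number that more compound is tolerated), compound 1 gives > 50000 nM, which is a limit of the assay.
- compound 2, `Nc1ccc2c(c1)S(=O)(=O)C=C(c1c(O)c3cc(F)ccc3n(Cc3ccc(F)cc3)c1=O)N2`; in this assay compound 2 gives > 50000 nM, also a limit.
- compound 3, `NS(=O)(=O)Nc1ccc2c(c1)S(=O)(=O)C=C(c1c(O)c3cc(F)ccc3n(Cc3ccc(F)cc3)c1=O)N2`; in this assay compound 3 gives > 50000 nM, again a limit.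

Compound 3 therefore stands at the limit shared by every value in this set (the limit of > 50000 nM in this assay, at which 3 of the 3 values shown sit); no number separates it from the others. The steps within the measured set, a step that the two limits leave unreadable from compound 1 to compound 2, a step that the two limits leave unreadable from compound 1 to compound 3 and a step that the two limits leave unreadable from compound 2 to compound 3, all run between two limits and their size cannot be read.

Compound 4, `CN(c1ccc2c(c1)S(=O)(=O)C=C(c1c(O)c3cc(F)ccc3n(Cc3ccc(F)cc3)c1=O)N2)S(C)(=O)=O`, differs from compound 3 by methyl(methylsulfonyl)amino in place of sulfamoylamino on an aromatic carbon. Within the data shown here, the steps that bear on this change are those ending at compound 3, a step that the two limits leave unreadable from compound 1 to compound 3 and a step that the two limits leave unreadable from compound 2 to compound 3, which alter the same aromatic carbon; both are unreadable in size, so no direction can be taken from them. Nothing in the measured set shows any compound leaving the limit. In this assay compound 4 is therefore expected to remain at the limit as well, with the expected step that the limit leaves unreadable from compound 3 to compound 4 reflecting no readable change. Compound 4 is estimated at 60000 nM, with a range from 25000 nM to 150000 nM.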

Compound 4, half-maximal cytotoxic concentration: > 50000 nM
Compound 4 was reported as a limit (the forecaster's own chance of this, stated with the estimate: 85%); the middle value is on the limit's open side.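

Compound 4 sits at the same limit as compound 1, compound 2 and compound 3, so none of the steps from these compounds to compound 4 can be read in size: the limit of > 50000 nM in this assay, at which 4 of the 4 values shown sit.

The compounds shown leave open where any of the four lies in this assay, and whether any group on this aromatic carbon would bring a compound off the limit.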